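Working notes: from compound 3 to compound 4

A few compounds are considered here, and "the series" means these few. Any claim that something is new, unique, unknown or untested is made for them only; others in the source may bear on it.

Measured in a functional assay on HL-60 cells (Homo sapiens) for cytotoxicity, read by luminescence and CellTiter-Glo, with a stated time of 3 days; on this read-out lower numbers stand for stronger inhibition and higher numbers for weaker inhibition:
compound 1 `O=C(Nc1cc(C(F)(F)F)cc(C(F)(F)F)c1)c1ccc(Br)cc1O`: 270 nM
compound 2 `O=C(Nc1cc(C(F)(F)F)cc(C(F)(F)F)c1)c1ccc(-c2ccccc2)cc1O`: 1140 nM
compound 3 `O=C(Nc1cc(C(F)(F)F)cc(C(F)(F)F)c1)c1cc(F)ccc1O`: 320 nM

Compound 3 stands at 320 nM, within the scatter of compound 1 at 270 nM. Compound 2 gives the highest number of the three at 1140 nM.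

The next compound is compound 4 `O=C(Nc1cc(C(F)(F)F)cc(C(F)(F)F)c1)c1ccc(Cl)cc1O`, still to be measured. The change is 4-chloro-2-hydroxyphenyl in place of 5-fluoro-2-hydroxyphenyl on a carbonyl carbon.

The closest guide is a 1.2-fold higher number from compound 1 to compound 3 (0.07 log units; within the scatter). That step exchanged 4-bromo-2-hydroxyphenyl for 5-fluoro-2-hydroxyphenyl on the same carbonyl carbon. The other measured step, a 4.2-fold higher number from compound 1 to compound 2 (0.63 log units; beyond the scatter), put phenyl in place of bromo and is the only one of the two beyond the scatter. No phenyl enters in compound 4, so that step bears on it only weakly. Among the compounds with values here, no compound carrying chloro has been measured yet, which leaves the estimate wide.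

No step beyond the scatter is expected in this assay, and no direction can be called. The expected step is a 1.1-fold lower number from compound 3 to compound 4 (0.04 log units; within the scatter). Compound 4 is estimated at 290 nM, with an expected range from 140 nM to 600 nM.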

Compound 4, half-maximal inhibitory concentration: 200 nM
Beside the measured number, compound 4's estimate is 1.5-fold (0.16 log units) above it; the range from low to high includes it.
By their numbers in this assay, from the lowest: compounds 4, 1 and 3 (each within the scatter of the next); then compound 2.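

In this assay, chloro in place of bromo on the aromatic carbon gives a 1.4-fold lower number from compound 1 to compound 4 (0.13 log units; within the scatter), and 4-chloro-2-hydroxyphenyl in place of 5-fluoro-2-hydroxyphenyl on the carbonyl carbon gives a 1.6-fold lower number from compound 3 to compound 4 (0.20 log units; within the scatter), so the three halogen-bearing compounds, compound 1, compound 3 and compound 4, sit within the scatter of one another. Chloro in place of phenyl gives a 5.7-fold lower number from compound 2 to compound 4 (0.76 log units; beyond the scatter), beyond the scatter, so a second halogen now confirms that compound 2 alone stands apart from the halogen-bearing compounds. Nothing on hand offers an explanation for either the closeness among the halogens or the gap to the phenyl compound.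

As far as these compounds go, it remains open whether a small non-halogen group at the place of chloro, such as methyl, methoxy, an amine or a carboxylic acid, would stay with the halogen-bearing compounds or fall with compound 2. Also open, from the compounds shown here alone, is whether fluoro and chloro would read alike if exchanged on the same aromatic carbon, since compound 3 and compound 4 differ in where the halogen stands as well as in which halogen it is.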